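A few compounds are considered here, and "the series" means these few. Any claim that something is new, unique, unknown or untested is made for them only; others in the source may bear on it.

Compound 1 `O=S(=O)(Nc1cc(CO)ccc1O)c1ccc(-c2ccc(Br)cc2)cc1`: 1000 nM
Compound 2 `O=S(=O)(Nc1cccc(CO)c1)c1ccc(-c2ccc3[nH]ccc3c2)cc1`: > 5000 nM

Both compounds were tested in a functional assay on J774 cells (Mus musculus) for cytotoxicity, read by resazurin assay, with a stated time of 72 h; a lower number here means a stronger inhibitor, a higher number a weaker inhibitor. Compound 2 stands at > 5000 nM, which is a limit of the assay and not a number. Its place is given by the limit of > 5000 nM in this assay, at which 1 of the 2 values shown sits.

Compound 3 `O=S(=O)(Nc1cccc(CO)c1)c1ccc(-c2ccc(F)cc2)cc1` keeps the core of compound 2 and changes one group: 4-fluorophenyl in place of 1H-indol-5-yl on an aromatic carbon. The 4-fluorophenyl sits in place of 1H-indol-5-yl on an aromatic carbon, para to a large group.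

For the measured compounds named here, no measured pair shows this swap, so any expectation is loose. A small step toward stronger inhibition in this assay is expected, or none beyond the scatter. This rests on compound 1 at 1000 nM, which differs from compound 2 in more than one place. The expected change is an at least 1.2-fold lower number from compound 2 to compound 3 (0.09 log units; that floor lies within the scatter). For compound 3 the estimated value is 4000 nM, with an expected range of 1500 nM to 10000 nM.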

Compound 3, half-maximal inhibitory concentration: 3500 nM
The estimate for compound 3 lay 1.1-fold (0.06 log units) above the measured number; the measured number falls inside the stated range.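

In this assay, placing 4-fluorophenyl instead of 1H-indol-5-yl on this aromatic carbon, para to a large group, gives an at least 1.4-fold lower number from compound 2 to compound 3 (0.15 log units; that floor lies within the scatter). Compound 2 stands at a limit of the assay and not at a number, so this step has only a floor: the limit of > 5000 nM in this assay, at which 1 of the 3 values shown sits.
Compound 3 gives a real number, 3500 nM, so the change now has a measured end on one side. From the compounds shown here alone, the true size of the step stays unknown, though, and its floor does not separate the two groups from ordinary scatter.

The compounds shown leave open whether the fluorine itself plays any part in this reading, or whether the plain six-membered aromatic ring would read the same. They also leave open how an amine or a carboxylic acid in place of the fluorine would read at this position.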